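The source may hold more compounds than are shown below. What is called first, only, known or untested is meant among the compounds shown, and "the series" means these compounds.

Compound 1 `CC(C)C(=O)NC(C(=O)N1CCC(c2ccc(Cl)cc2)CC1)C(C)C`: 388 nM
Compound 2 `Cc1ccc(C(=O)N[C@@H](C(=O)N2CCC(c3ccc(Cl)cc3)CC2)C(C)C)cc1`: 25 nM
Compound 3 `CC(C)C(NC(=O)c1ccccc1)C(=O)N1CCC(c2ccc(F)cc2)CC1`: 423 nM

These three compounds were tested in an assay on THP-1 cells for displacement of a labelled ligand from C-C chemokine receptor type 1 (Homo sapiens); a higher number here means a weaker inhibitor, a lower number a stronger inhibitor. Compound 2 gives the lowest number of the three, and its gaps to compound 1 and to compound 3 both lie beyond the usual scatter, so compound 2 is the strongest inhibitor measured so far. Compound 4 `CC(C)[C@@H](NC(=O)CC1CC1)C(=O)N1CCC(c2ccc(Cl)cc2)CC1` has not yet been measured. It differs from compound 2 in one place: cyclopropylmethyl in place of 4-methylphenyl on a carbonyl carbon. Compound 1, which likewise carries no aromatic ring on that carbonyl carbon, gives 388 nM, a clearly weaker result than compound 2. On that basis a step upward, beyond the scatter, is expected, of about a 10-fold higher number from compound 2 to compound 4 (1.00 log units; beyond the scatter). Compound 4 is thus expected to give roughly 250 nM, somewhere between 80 nM and 800 nM.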

Compound 4, half-maximal inhibitory concentration: 46 nM
The estimate for compound 4 lay 5.4-fold (0.74 log units) above the measured number; the whole stated range lies above it.
By their numbers in this assay, from the lowest: compounds 2 and 4 (each within the scatter of the next); then compounds 1 and 3 (each within the scatter of the next).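

In this assay the change from 4-methylphenyl to cyclopropylmethyl on a carbonyl carbon gives a 1.8-fold higher number from compound 2 to compound 4 (0.26 log units; within the scatter) and so no clear difference. An aromatic ring at this position is therefore not needed to reach this level of inhibition: a three-membered non-aromatic ring group with 4 heavy atoms, in place of one with 7, serves within the scatter. No measurement available here explains this match.

On these data alone, how a carboxylic acid or an amine on this carbonyl carbon would read in this assay remains open. So does the effect of a longer carbon chain there.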